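Removing a Methyl Group in Two Related Cytotoxicity Series

This account rests on a few compounds, and the source may have more. Where it says the series, first, only, none or still open, it means among the compounds named here.

Compound 1, `Cc1ccc2nc(Nc3nc4ccccc4s3)sc2c1`: 48400 nM in a functional assay on U-937 cells (Homo sapiens) for cytotoxicity, read by MTT assay, with a stated time of 48 h; on this read-out lower numbers stand for stronger inhibition and higher numbers for weaker inhibition
Compound 3, `c1ccc2sc(Nc3nc4ccccc4s3)nc2c1`: 40000 nM
Compound 2, `Cc1ccc2nc(NC(=S)Nc3ccccc3)sc2c1`: > 50000 nM, which is a limit of the assay and not a number

Compounds 1 and 3 share a core and differ by one change, (hydrogen in place of methyl on an aromatic carbon). This change gives a 1.2-fold lower number from compound 1 to compound 3 (0.08 log units; within the scatter), so in this assay the two compounds cannot be told apart. Compound 2 has a different core; the difference between the two cores is not broken down here. For compound 2 only a limit is known, (the limit of > 50000 nM in this assay, at which 1 of the 3 values shown sits).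

Compound 4, `S=C(Nc1ccccc1)Nc1nc2ccccc2s1`, is not yet measured. It differs from compound 2 by hydrogen in place of methyl on an aromatic carbon, the same change that turns compound 1 into compound 3. Since that earlier step stayed within the scatter, the step from compound 2 to compound 4 is expected to be small as well, estimated at a step that the limit leaves unreadable from compound 2 to compound 4. Because compound 2 sits at the limit, compound 4 is expected to land near that limit too, with an estimate of 55000 nM and a likely range from 30000 nM to 110000 nM, and a fair chance that only a limit is reported again.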

Compound 4, half-maximal inhibitory concentration: > 50000 nM
Compound 4 was reported as a limit (the forecaster's own chance of this, stated with the estimate: 65%); the middle value lies beyond the limit too.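

Compound 2 and compound 4 are each reported in this assay only as a limit of the assay, not as a number, so no step can be read between them: the limit of > 50000 nM in this assay, at which 2 of the 4 values shown sit.

The compounds shown leave open whether replacing methyl with hydrogen changes the value in this pair as little as it does between compound 1 and compound 3.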